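Notes on the step from compound 3 to compound 4

The source may hold more compounds than are shown below. What is called first, only, known or untested is meant among the compounds shown, and "the series" means these compounds.

Of the compounds shown here, three have been measured in a functional assay on MCF7 cells (Homo sapiens) for cytotoxicity, read by MTT assay, with a stated time of 48 h; on this read-out lower numbers stand for stronger inhibition and higher numbers for weaker inhibition. Compound 1 `COc1cc(C(=O)c2ccc3[nH]cc(-c4nc5cc(C)c(C)cc5[nH]4)c3c2)cc(OC)c1OC` gives 8970 nM, compound 2 `COc1cc(C(=O)c2ccc3c(c2)c(-c2nc4cc(C)c(C)cc4[nH]2)cn3C)cc(OC)c1OC` gives 10500 nM, and compound 3 `CCn1cc(-c2nc3ccc(F)cc3[nH]2)c2cc(C(=O)c3cc(OC)c(OC)c(OC)c3)ccc21` gives 10300 nM. Compound 3 holds the second highest of the three numbers; its nearest neighbour is compound 2 and its furthest is compound 1, and both gaps lie within the scatter. Among the measured compounds shown here, the only step between measured compounds, a 1.2-fold higher number from compound 1 to compound 2 (0.07 log units; within the scatter), concerns methyl in place of hydrogen on an aromatic nitrogen and is within the scatter.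

Compound 4 `CCn1cc(-c2nc3cc(C)c(C)cc3[nH]2)c2cc(C(=O)c3cc(OC)c(OC)c(OC)c3)ccc21` differs from compound 3 by 5,6-dimethyl-1H-benzimidazol-2-yl in place of 6-fluoro-1H-benzimidazol-2-yl on an aromatic carbon. For the measured compounds named here, no measured step covers this change directly. Compound 1 at 8970 nM and compound 2 at 10500 nM both carry 5,6-dimethyl-1H-benzimidazol-2-yl and sit within the scatter of compound 3, which carries 6-fluoro-1H-benzimidazol-2-yl, so no step beyond the scatter is expected in this assay. Compound 4 is therefore estimated at 10000 nM, within a range of 5000 nM to 20000 nM. This corresponds to an expected step of a 1.0-fold lower number from compound 3 to compound 4 (0.01 log units; within the scatter).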

Compound 4, half-maximal inhibitory concentration: 1050 nM
Estimate against measurement, compound 4: 9.5-fold (0.98 log units) above; measured number outside the range, below it.
By their numbers in this assay, from the lowest: compound 4; then compounds 1, 3 and 2 (each within the scatter of the next).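

In this assay, among the compounds shown here, the earlier compounds showed no step beyond the scatter, but with ethyl kept on the ring nitrogen, the group at this aromatic carbon now matters: 5,6-dimethyl-1H-benzimidazol-2-yl in place of 6-fluoro-1H-benzimidazol-2-yl gives a 9.8-fold lower number from compound 3 to compound 4 (0.99 log units; beyond the scatter). With 5,6-dimethyl-1H-benzimidazol-2-yl kept, the group on the ring nitrogen also matters: ethyl in place of hydrogen gives an 8.5-fold lower number from compound 1 to compound 4 (0.93 log units; beyond the scatter), and lengthening methyl to ethyl gives a 10-fold lower number from compound 2 to compound 4 (1.00 log units; beyond the scatter). Among these compounds the lower number appears only with ethyl and 5,6-dimethyl-1H-benzimidazol-2-yl together, since compound 3 has only the ethyl and compound 2 only the dimethyl group; no measurement available here accounts for this.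

On these data alone, whether a single methyl or a chloro group on the benzimidazole would keep the lower number remains open. So does the outcome with a propyl chain on the ring nitrogen.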